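Cyano in place of trifluoromethoxy: the step to compound 4

The source may report more compounds than this note shows. Statements on the series, on what has been measured and on what is new or still open speak of the compounds shown alone.

Measured so far in a functional assay on DU-145 cells (Homo sapiens) for antiproliferative activity, read by propidium iodide staining, with a stated time of 96 h (on this read-out higher numbers stand for weaker inhibition and lower numbers for stronger inhibition), on the shared core:
- compound 1 `CC(O)(CSc1ccc(F)cc1)C(=O)Nc1ccc(S(F)(F)(F)(F)F)cc1` gives 25400 nM
- compound 2 `CC(O)(COc1ccc(S(F)(F)(F)(F)F)cc1)C(=O)Nc1ccc(S(F)(F)(F)(F)F)cc1` gives 24900 nM
- compound 3 `CC(O)(COc1ccc(OC(F)(F)F)cc1)C(=O)Nc1ccc(S(F)(F)(F)(F)F)cc1` gives 24800 nM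

Compound 3 stands level with compound 1 and compound 2, all three values lying within the scatter of one another. Compound 4 `CC(O)(COc1ccc(C#N)cc1)C(=O)Nc1ccc(S(F)(F)(F)(F)F)cc1` follows from compound 3 by cyano in place of trifluoromethoxy on an aromatic carbon with cyano in place of trifluoromethoxy on an aromatic carbon, para to a large group. Going by the values given here, the one measured step at this place is a 1.0-fold lower number from compound 2 to compound 3 (0.00 log units; within the scatter) and it lies within the scatter. Among the compounds with values here, no measured compound carries cyano, so that step is the only guide. No step beyond the scatter is therefore expected in this assay for this change. The expected step is a 1.0-fold higher number from compound 3 to compound 4 (0.00 log units; within the scatter) and it remains an estimate. For compound 4 the estimated value is 25000 nM with an expected range from 12000 nM to 50000 nM in this read-out.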

Compound 4, half-maximal inhibitory concentration: 32200 nM
For compound 4 the middle estimate is 1.3-fold (0.11 log units) below the measured one; low and high end bracket the measured number.
By their numbers in this assay, from the lowest: compounds 3, 2, 1 and 4 (each within the scatter of the next).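

In this assay, cyano reads level with the larger groups at this place on the aromatic ring (a 1.3-fold higher number from compound 3 to compound 4 (0.11 log units; within the scatter); a 1.3-fold higher number from compound 2 to compound 4 (0.11 log units; within the scatter)). Exchanging (4-fluorophenyl)sulfanyl for 4-cyanophenoxy on the saturated chain carbon also stays within the scatter (a 1.3-fold higher number from compound 1 to compound 4 (0.10 log units; within the scatter)), so the four compounds show no separation. Nothing at hand accounts for this flat reading.

Going by these compounds, how an amine or a carboxylic acid at this place would read stays open. Also open, on these data alone, is whether any change on the shared core moves the number beyond the scatter.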